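The source may hold more compounds than are shown below. What is called first, only, known or untested is meant among the compounds shown, and "the series" means these compounds.

Measured compounds:
compound 1, `NC(=O)CC[C@H](NC(=O)CN(c1ncnc2c1ncn2C1CCCCO1)C1CC1)C(=O)OCc1ccccc1`, 37.8%
compound 2, `C[C@H](NC(=O)CN(c1ncnc2c1ncn2C1CCCCO1)C1CC1)C(=O)OCc1ccccc1`, 32.1%
compound 3, `NC(=O)CC[C@H](NC(=O)CN(c1nc(Cl)nc2[nH]cnc12)C1CC1)C(=O)O`, 41.1%

In a functional assay on the whole organism (Tail, strain ICR) with Mus musculus as the target, in the tail flick test, with a stated time of 90 min, at a dose of 25 umol/kg by the oral route (on this read-out higher numbers stand for a stronger effect at the one dose given and lower numbers for a weaker effect), compound 1 gives 37.8% and compound 2 gives 32.1%. The two differ by one change, (hydrogen in place of carbamoylmethyl on a saturated chain carbon, two bonds along the chain from an amide-type nitrogen and a carbonyl carbon), and the step it made is a number 5.7 percentage points lower from compound 1 to compound 2 (within the scatter). Compound 3 carries a different core and a free carboxylic acid in place of the benzyl ester; the difference between the two cores is not broken down here. In this assay compound 3 gives 41.1%, a number that lies within the scatter of compound 1 and of compound 2.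

Compound 4, `C[C@H](NC(=O)CN(c1nc(Cl)nc2[nH]cnc12)C1CC1)C(=O)O`, has not been measured. It differs from compound 3 by hydrogen in place of carbamoylmethyl on a saturated chain carbon, two bonds along the chain from an amide-type nitrogen and a carbonyl carbon, the same change that separates compound 1 from compound 2, at the same place. Because the earlier step was a number 5.7 percentage points lower from compound 1 to compound 2 (within the scatter), the step from compound 3 to compound 4 is expected to be of like size, a number 5.1 percentage points lower from compound 3 to compound 4 (within the scatter), and to stay within the scatter. On that basis compound 4 is estimated at 36% in this assay, between 22% and 50%.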

Compound 4, a percentage reported as activity, at one dose (the size of the read-out at that dose, not a potency): 43.5%
Beside the measured number, compound 4's estimate is 7.5 percentage points below it; the measured number falls inside the stated range.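

Carried to the second core, the swap of carbamoylmethyl for hydrogen gave, in this assay, a number 2.4 percentage points higher from compound 3 to compound 4 (within the scatter), while on the first core it gave a number 5.7 percentage points lower from compound 1 to compound 2 (within the scatter). The two steps carry opposite signs, but they cannot be told apart: the same change on two cores in this assay, a number 5.7 percentage points lower (within the scatter) from compound 1 to compound 2 and a number 2.4 percentage points higher (within the scatter) from compound 3 to compound 4, 8.1 percentage points apart, within the scatter of two such steps

Together they show that, on both cores, this change left the read-out within the usual scatter at the one dose given, and that nothing separates its outcome on one core from its outcome on the other. They do not show that a step of a set size carries over between cores, since neither step stands clear of the scatter, and a single dose says nothing about potency.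

The compounds shown leave open what an amine or a longer alkyl chain would do in place of carbamoylmethyl on that saturated chain carbon. They also leave open whether any such group would move the read-out beyond the scatter on either core.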